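This account rests on a few compounds, and the source may have more. Where it says the series, first, only, none or still open, it means among the compounds named here.

Compounds measured so far:
- compound 1, `CNc1nc(NCCCN(C)C)c2sc(-c3ccc(C(F)(F)F)cc3)cc2n1`: 240 ug/mL
- compound 2, `CNc1nc(N)c2sc(-c3ccc(C(F)(F)F)cc3)cc2n1`: > 100 ug/mL
- compound 3, `CNc1nc(Nc2cccc(C(N)=O)c2)c2sc(-c3ccc(C(F)(F)F)cc3)cc2n1`: 85 ug/mL

In a physicochemical assay for solubility, at pH 2 (a higher number here means a more soluble compound, a lower number a less soluble compound), compound 1 gives 240 ug/mL, the highest of the two plain numbers in the set. Compound 2 shows only a limit, > 100 ug/mL, in this assay. Within the data shown here, compound 3 gives 85 ug/mL, and the step of a 2.8-fold lower number from compound 1 to compound 3 (0.45 log units; beyond the scatter) is the one change that falls beyond the scatter; the step of an at least 1.1-fold lower number from compound 2 to compound 3 (0.07 log units; that floor lies within the scatter) stays inside it, and the step that the limit leaves unreadable from compound 1 to compound 2 cannot be sized because of the limit (the limit of > 100 ug/mL in this assay, at which 1 of the 3 values shown sits).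

Compound 4, `CN(C)CCCNc1ncnc2cc(-c3ccc(C(F)(F)F)cc3)sc12`, differs from compound 1 by hydrogen in place of methylamino on an aromatic carbon. Every measured step changes the other nitrogen of the core, the one carrying the 3-(dimethylamino)propyl chain, which compound 4 keeps. Among the measured compounds shown here, no measured step touches the methylamino position, so no step bears on this change. The expectation is therefore no step beyond the scatter from compound 1 to compound 4, and a wide range: compound 4 is estimated at 200 ug/mL in this assay, between 60 ug/mL and 600 ug/mL, a step of a 1.2-fold lower number from compound 1 to compound 4 (0.08 log units; within the scatter).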

Compound 4, solubility: 209 ug/mL
Compound 4: middle estimate off by 1.0-fold (0.02 log units), on the low side; measured number inside the range.
By their numbers in this assay, from the lowest: compound 3; then compounds 4 and 1 (each within the scatter of the next).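

In this assay, among these compounds, the methylamino position now has a measured step of its own, which the earlier compounds did not give: with hydrogen in place of methylamino on the aromatic carbon between two ring nitrogen atoms, the result is a 1.1-fold lower number from compound 1 to compound 4 (0.06 log units; within the scatter). With the (3-(dimethylamino)propyl)amino group kept, the methylamino group can therefore be lost without a change beyond the scatter, at least in this one pair. Nothing measured here offers a reason for this outcome.

Going by these compounds, this reading rests on a single pair, and whether it carries over to compounds with the 3-carbamoylphenyl group on the other nitrogen stays open. On these data alone, how this assay responds to other groups on this carbon, such as an unsubstituted amine, a methoxy group or a longer alkylamino chain, also stays open.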